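Shifting the indole attachment in an arylpiperazine amide series

A few compounds are considered here, and "the series" means these few. Any claim that something is new, unique, unknown or untested is made for them only; others in the source may bear on it.

Measured compounds in an assay on isolated protein (Vas deferens, strain Sprague-Dawley) for antagonist activity at Alpha-1A adrenergic receptor (Rattus norvegicus), with a stated time of 20 min; a lower number here means tighter binding, a higher number weaker binding:
Compound 1 `COc1ccccc1N1CCN(CCCNC(=O)c2ccc3[nH]ccc3c2)CC1` gives 26.3 nM.
Compound 2 `COc1ccccc1N1CCN(CCCNC(=O)c2cc3cc(O)ccc3[nH]2)CC1` gives 55 nM.
Compound 3 `COc1ccccc1N1CCN(CCCNC(=O)c2cc3cccc([N+](=O)[O-])c3[nH]2)CC1` gives 58.9 nM.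

Compound 1 holds the lowest number of the three; compound 2 lies a step away, a 2.1-fold higher number from compound 1 to compound 2 (0.32 log units; beyond the scatter), and compound 3 sits slightly further off. Compound 4 `COc1ccccc1N1CCN(CCCNC(=O)c2cn(C)c3ccccc23)CC1` differs from compound 1 by 1-methyl-1H-indol-3-yl in place of 1H-indol-5-yl on a carbonyl carbon. For the measured compounds named here, the only measured step that bears on this change is the indole rearrangement from compound 1 to compound 2, which was modest; the value of compound 3 sits in the same region. A comparable modest weakening is therefore expected for compound 4, about a 2.1-fold higher number from compound 1 to compound 4 (0.32 log units; beyond the scatter) in this assay. Compound 4 is estimated at 55 nM, within 18 nM to 170 nM.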

Compound 4, dissociation constant: 52.5 nM
For compound 4 the middle estimate is 1.0-fold (0.02 log units) above the measured one; the range from low to high includes it.
By their numbers in this assay, from the lowest: compounds 1, 4, 2 and 3 (each within the scatter of the next, the first and the last beyond it).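

In this assay, putting 1-methyl-1H-indol-3-yl in place of 1H-indol-5-yl on the carbonyl carbon gives a 2.0-fold higher number from compound 1 to compound 4 (0.30 log units; within the scatter) and so stays within the scatter, even though the hydrogen-bond donor counted on the leaving group is gone. The comparison with 5-hydroxy-1H-indol-2-yl gives a 1.0-fold lower number from compound 2 to compound 4 (0.02 log units; within the scatter) and does not separate these two groups. No available evidence explains either reading. Still open, on these data alone, is how 1H-indol-3-yl without the methyl would read, which would separate the methyl from the change of attachment, and how a carboxylic acid or an amine would read on that carbonyl carbon.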